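Ethoxy on the aromatic ring of compound 1

The source may report more compounds than this note shows. Statements on the series, on what has been measured and on what is new or still open speak of the compounds shown alone.

In an in vivo ADME assay on the whole organism (plasma, Rattus norvegicus, strain Sprague-Dawley) for pharmacokinetics, with a stated time of 4 h, at a dose of 5 mg/kg by the oral route (a lower number here means less compound in the circulation, a higher number more compound in the circulation at the dose given), compound 1 `C=C[C@@H]1C[C@]1(NC(=O)[C@@H]1C[C@@H]2CN1C(=O)[C@H](C(C)(C)C)NC(=O)OCCCCCc1ccc3ccnc(c3c1)O2)C(=O)NS(=O)(=O)C1CC1` gives 188 ng.h/mL and stands lowest of the three measured compounds, with compound 2 `C=C[C@@H]1C[C@]1(NC(=O)[C@@H]1C[C@@H]2CN1C(=O)[C@H](C1CCOCC1)NC(=O)OCCCCCc1ccc3ccnc(c3c1)O2)C(=O)NS(=O)(=O)C1CC1` at 579 ng.h/mL and compound 3 `C=C[C@@H]1C[C@]1(NC(=O)[C@@H]1C[C@@H]2CN1C(=O)[C@H](C(C)(C)C)NC(=O)OCCCCCc1cc3c(nccc3cc1OC)O2)C(=O)NS(=O)(=O)C1CC1` at 6970 ng.h/mL as the higher numbers. Compound 4 `C=C[C@@H]1C[C@]1(NC(=O)[C@@H]1C[C@@H]2CN1C(=O)[C@H](C(C)(C)C)NC(=O)OCCCCCc1cc(OCC)c3ccnc(c3c1)O2)C(=O)NS(=O)(=O)C1CC1` is not yet measured. Against compound 1 it carries ethoxy in place of hydrogen on an aromatic carbon of a six-membered aromatic ring of carbon only, ortho to a fused ring. The nearest measured change is methoxy in place of hydrogen on an aromatic carbon, the large step of a 37-fold higher number from compound 1 to compound 3 (1.57 log units; beyond the scatter) but compound 3 holds its methoxy on a different aromatic carbon, so that step is only a loose guide. The modest step of a 3.1-fold higher number from compound 1 to compound 2 (0.49 log units; beyond the scatter) is a change of another kind, oxan-4-yl in place of tert-butyl, and bears only indirectly. A rise in this assay is therefore expected, well short of the methoxy step, and the estimated move is a 5.3-fold higher number from compound 1 to compound 4 (0.73 log units; beyond the scatter) in that upward direction. The estimate for compound 4 is 1000 ng.h/mL with an expected range of 220 ng.h/mL to 5000 ng.h/mL on this single loose precedent.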

Compound 4, area under the concentration-time curve: 5110 ng.h/mL
Compound 4: the middle estimate sits 5.1-fold (0.71 log units) below what was measured; measured number outside the range, above it.
By their numbers in this assay, from the lowest: compound 1; then compound 2; then compounds 4 and 3 (each within the scatter of the next).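

In this assay, ethoxy on an aromatic carbon ortho to a fused ring gives a 27-fold higher number from compound 1 to compound 4 (1.43 log units; beyond the scatter), so a large rise is not confined to the carbon that holds the methoxy group of compound 3. That step is of the same large class as a 37-fold higher number from compound 1 to compound 3 (1.57 log units; beyond the scatter) and is greater in size than the modest 3.1-fold higher number from compound 1 to compound 2 (0.49 log units; beyond the scatter), which comes from a change elsewhere in the molecule. No evidence at hand accounts for the rise.

Open, from the compounds shown here alone, is whether the rise at this carbon needs the ether oxygen, or also holds for methyl, a longer chain such as propoxy, or an amine. Also open, going by these compounds, is whether ethoxy here adds to the gain from oxan-4-yl in place of tert-butyl.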